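Replacing 2-methoxyphenyl with 4-methylphenyl on an amide-type nitrogen

This account rests on a few compounds, and the source may have more. Where it says the series, first, only, none or still open, it means among the compounds named here.

In an ADME assay on THP-1 cells (Homo sapiens) for cytotoxicity (on this read-out lower numbers stand for higher toxicity in this test and higher numbers for lower toxicity in this test), compound 3 (`COc1ccccc1NC(=O)c1c(NC(=O)C(F)(F)F)sc2c1CCCCC2`) gives > 50000 nM, which is a limit and not a number. Compound 1 (`O=C(Nc1ccc(Cl)cc1)c1c(NC(=O)C(F)(F)F)sc2c1CCCCC2`) gives > 50000 nM, also a limit. For the measured compounds named here, compound 2 (`COc1cccc(NC(=O)c2c(NC(=O)C(F)(F)F)sc3c2CCCCC3)c1`) gives 37600 nM, the only actual number so far.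

Compound 4 (`Cc1ccc(NC(=O)c2c(NC(=O)C(F)(F)F)sc3c2CCCCC3)cc1`) differs from compound 3 by this change: 4-methylphenyl in place of 2-methoxyphenyl on an amide-type nitrogen.

Two swaps at the same nitrogen offer a guide: an at least 1.3-fold lower number from compound 1 to compound 2 (0.12 log units; that floor lies within the scatter), and an at least 1.3-fold higher number from compound 2 to compound 3 (0.12 log units; that floor lies within the scatter). A third, a step that the two limits leave unreadable from compound 1 to compound 3, gives no size. None of these is shown to exceed the scatter, so no step beyond the scatter is expected here.

In this assay the expected step is an at least 1.1-fold lower number from compound 3 to compound 4 (0.04 log units; that floor lies within the scatter). For compound 4 the estimated value is 45000 nM, with an expected range of 25000 nM to 80000 nM.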

Compound 4, half-maximal cytotoxic concentration: > 50000 nM
Compound 4: only a limit was reported; the forecaster's own chance of this, stated with the estimate: 55%; middle value at least 1.1-fold (0.04 log units) from the limit.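

In this assay, compound 4 gives a limit, not a number, so 4-methylphenyl on this amide-type nitrogen reads like 2-methoxyphenyl and 4-chlorophenyl, and the steps among compounds 1, 3 and 4 cannot be read. The only readable step is an at least 1.3-fold higher number from compound 2 to compound 4 (0.12 log units; that floor lies within the scatter), so this swap is not shown to change the read-out. The assay therefore says little about this change: the limit of > 50000 nM in this assay, at which 3 of the 4 values shown sit.

As far as these compounds go, whether any group on this nitrogen gives a step beyond the scatter stays open. So does how an amine or a carboxylic acid on the phenyl ring would read.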